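The compounds below may be only part of what the source reports. "The series", "measured", "known", "first", "only" and "open" are said of these compounds alone.

Two compounds that share one core have been examined in an assay on CHO-K1 cells for displacement of a labelled ligand from melanin-concentrating hormone receptor 1 (Homo sapiens), with a stated time of 2 h; a higher number here means a weaker inhibitor, a lower number a stronger inhibitor. Compound 1 `Cc1nc(N2CCC(C)(O)CC2)nc2ccc(NC(=O)COc3ccc(Cl)cc3)cc12` gives 237 nM in this assay, which is the higher of the two numbers recorded so far. Compound 2 `Cc1nc(N2CCC(O)(C3CC3)CC2)nc2ccc(NC(=O)COc3ccc(OC(F)(F)F)cc3)cc12` gives 101 nM in this assay, a lower number than that of compound 1 by a margin that lies beyond the usual scatter; compound 2 differs from compound 1 in more than one place, so no single change can be held responsible for that gap.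

Compound 3 `Cc1nc(N2CCN(CC(C)(C)C)CC2)nc2ccc(NC(=O)COc3ccc(Cl)cc3)cc12` has not yet been measured. It differs from compound 1 in one place: 4-neopentylpiperazin-1-yl in place of 4-hydroxy-4-methylpiperidin-1-yl on an aromatic carbon. With no step between measured compounds that isolates this change, any expectation rests on the numbers already shown. The step from compound 1 to compound 3 is expected to be a 1.8-fold lower number from compound 1 to compound 3 (0.26 log units; within the scatter), a modest move toward a lower number. Compound 3 is estimated to give 130 nM in this assay, within a range from 35 nM to 500 nM.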

Compound 3, half-maximal inhibitory concentration: 782 nM
The estimate for compound 3 lay 6.0-fold (0.78 log units) below the measured number; measured number above the stated range.
By their numbers in this assay, from the lowest: compound 2; then compound 1; then compound 3.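

In this assay, placing 4-neopentylpiperazin-1-yl where compound 1 carries 4-hydroxy-4-methylpiperidin-1-yl gives a 3.3-fold higher number from compound 1 to compound 3 (0.52 log units; beyond the scatter), so the group on this aromatic carbon between the two ring nitrogen atoms clearly affects inhibition, and this replacement weakens it. The swap alters several features at once: the entering group has a second ring nitrogen and more heavy atoms, and it lacks the hydrogen-bond donor of the group it replaces. Nothing available shows which of these differences matters for the result.

The compounds shown leave open whether the ring or its side chain drives the step, which a piperazine bearing only a methyl group could help separate. They also leave open whether the same replacement would give a similar step in a compound carrying the trifluoromethoxy group of compound 2.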